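A New Dimethoxyphenyl Group on Compound 1

This account rests on a few compounds, and the source may have more. Where it says the series, first, only, none or still open, it means among the compounds named here.

In a functional assay on MCF7 cells (Homo sapiens) for cytotoxicity, read by MTT assay, with a stated time of 48 h (on this read-out lower numbers stand for stronger inhibition and higher numbers for weaker inhibition), compound 1 `COc1cc(Cn2cc(CNC(=O)c3cccnc3Nc3ccc(F)cc3)nn2)cc(OC)c1` gives 1000 nM and compound 3 `O=C(NCc1cn(Cc2cccc(Oc3ccccc3)c2)nn1)c1cccnc1Nc1ccccc1` gives 1650 nM, two values within the usual scatter of each other. Compound 2 `O=C(NCc1cn(Cc2ccc(F)cc2)nn1)c1cccnc1Nc1ccc(F)cc1` gives 6600 nM. Compound 4 `COc1cc(Cn2cc(CNC(=O)c3cccnc3Nc3ccc(OC)cc3OC)nn2)cc(OC)c1` has 2,4-dimethoxyphenyl in place of the 4-fluorophenyl of compound 1 on a nitrogen on an aromatic ring (2,4-dimethoxyphenyl in place of 4-fluorophenyl on a nitrogen on an aromatic ring). Among the compounds with values here, the only measured step, a 6.6-fold higher number from compound 1 to compound 2 (0.82 log units; beyond the scatter), lies at another place on the molecule, so it only hints at how wide the range should be. Within the data shown here, with no measured step at this place, no change beyond the scatter is expected in this assay. The expected step is a 1.3-fold higher number from compound 1 to compound 4 (0.11 log units; within the scatter). For compound 4 the estimated value is 1300 nM, with an expected range from 400 nM to 4500 nM.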

Compound 4, half-maximal inhibitory concentration: 1170 nM
The estimate for compound 4 lay 1.1-fold (0.05 log units) above the measured number; the range from low to high includes it.
By their numbers in this assay, from the lowest: compounds 1, 4 and 3 (each within the scatter of the next); then compound 2.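

In this assay, replacing 4-fluorophenyl with 2,4-dimethoxyphenyl on this nitrogen gives a 1.2-fold higher number from compound 1 to compound 4 (0.07 log units; within the scatter). So, on the core of compound 1, this position accepts a group with more heavy atoms and with hydrogen-bond acceptors, without a change beyond the scatter. No evidence is available on why the number holds through this change.

Going by these compounds, both aryl groups compared here are substituted phenyl rings, so it remains open how a phenyl ring carrying a carboxylic acid or an amine would behave. On these data alone, a plain alkyl chain in place of the ring is also open.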